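This account rests on a few compounds, and the source may have more. Where it says the series, first, only, none or still open, it means among the compounds named here.

Series notes. Compound 1 `COc1ccc(/C=C/C(=O)c2ccc(OC)c3c2OC(C)(C)C=C3)c(F)c1`, compound 2 `COc1cc(OC)c(OC)cc1/C=C/C(=O)c1ccc(OC)c2c1OC(C)(C)C=C2` and compound 3 `COc1ccc(C(=O)/C=C/c2ccc(F)cc2)c2c1C=CC(C)(C)O2` share one core and differ only in the aryl group on the double-bonded chain. In a functional assay on K562 cells (Homo sapiens) for antiproliferative activity, read by MTT assay, with a stated time of 24 h (a lower number here means a stronger inhibitor, a higher number a weaker inhibitor), compound 1 reaches only the limit of the assay, > 10000 nM. Compound 2 likewise gives only a limit, > 10000 nM. Compound 3 also stops at a limit, > 10000 nM. The step that the two limits leave unreadable from compound 1 to compound 3 is therefore unreadable, as the limit of > 10000 nM in this assay, at which 3 of the 3 values shown sit, shows. Compound 4 `COc1ccc(C(=O)/C=C/c2ccc(N3CCCC3)cc2)c2c1C=CC(C)(C)O2` differs from compound 3 by pyrrolidin-1-yl in place of fluoro on an aromatic carbon. Among the measured compounds shown here, no measured step touches this change, and every value so far in this assay is a limit, so nothing fixes the direction or size of the step. The expected step of an at least 1.2-fold lower number from compound 3 to compound 4 (0.09 log units; that floor lies within the scatter) is taken as small, within the scatter. Compound 4 is estimated at 8000 nM, with a range from 2000 nM to 40000 nM.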

Compound 4, half-maximal inhibitory concentration: 6180 nM
Beside the measured number, compound 4's estimate is 1.3-fold (0.11 log units) above it; measured number inside the range.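

In this assay, pyrrolidin-1-yl in place of fluoro, on the aromatic carbon para to a large group, gives an at least 1.6-fold lower number from compound 3 to compound 4 (0.20 log units; that floor lies within the scatter). Change at this position can thus bring the read-out within the measurable range, a result that the earlier limits could not show. Compound 4 is the only compound shown with a number, and the others give only a limit: the limit of > 10000 nM in this assay, at which 3 of the 4 values shown sit.

As far as these compounds go, the full size of the step stays open, with compound 3 held only at a limit. Also open, from the compounds shown here alone, is whether another amine at this position, such as piperidin-1-yl or dimethylamino, would give a number in the same range.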